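Swapping the pyrazole for cyclopropyl on the amide nitrogen

The source may report more compounds than this note shows. Statements on the series, on what has been measured and on what is new or still open speak of the compounds shown alone.

Measured compounds:
compound 1 `Cc1ccc(OCC(=O)N(O)Cc2cccs2)cc1` with 8000 nM
compound 2 `Cc1ccc(OCC(=O)N(Cc2cccs2)c2c[nH]nc2C)cc1` with 0.4 nM

In an assay on HEK293 cells for agonist activity at transient receptor potential cation channel subfamily M member 8 (Homo sapiens), read by fluorescence and calcium flux, with a stated time of 15 min (on this read-out higher numbers stand for an effect only at larger amounts of compound and lower numbers for an effect already at smaller amounts), compound 2 gives the lowest of the two numbers. Within the data shown here, its nearest neighbour is compound 1, reached by a 20000-fold lower number from compound 1 to compound 2 (4.30 log units; beyond the scatter), the only step measured so far. Compound 3 `Cc1ccc(OCC(=O)N(Cc2cccs2)C2CC2)cc1` carries cyclopropyl in place of 3-methyl-1H-pyrazol-4-yl on an amide-type nitrogen. Among the measured compounds shown here, the one measured step shows that what sits on this nitrogen weighs heavily, but cyclopropyl resembles neither group, so the step from compound 2 has no direct precedent. A loss is expected, estimated as a 250-fold higher number from compound 2 to compound 3 (2.40 log units; beyond the scatter), giving compound 3 an expected 100 nM with a range from 5 nM to 5000 nM.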

Compound 3, half-maximal effective concentration: 8 nM
Compound 3: the middle estimate sits 13-fold (1.10 log units) above what was measured; measured number inside the range.
By their numbers in this assay, from the lowest: compound 2; then compound 3; then compound 1.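

In this assay, the 3-methyl-1H-pyrazol-4-yl group proves not to be required for a low number, though replacing it with cyclopropyl, which carries no hydrogen-bond donor or acceptor, still gives a 20-fold higher number from compound 2 to compound 3 (1.30 log units; beyond the scatter). The all-carbon ring also retains much of the gain over hydroxy, with a 1000-fold lower number from compound 1 to compound 3 (3.00 log units; beyond the scatter). No evidence is available to explain either step. As far as these compounds go, it remains open whether the remaining gap tracks the donor and acceptor of the pyrazole or the size of the ring; phenyl or isopropyl on this nitrogen would help separate the two.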